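This account rests on a few compounds, and the source may have more. Where it says the series, first, only, none or still open, it means among the compounds named here.

In a functional assay on K562 cells (Homo sapiens) for antiproliferative activity, with a stated time of 72 h; a higher number here means a weaker inhibitor, a lower number a stronger inhibitor:

- compound 1 `CCCC#Cc1cc([C@@H]2O[C@H](CO)[C@@H](O)[C@H]2O)n2ncnc(N)c12`: 1100 nM
- compound 2 `Nc1ncnn2c([C@@H]3O[C@H](CO)[C@@H](O)[C@H]3O)cc(C#CC3CC3)c12`: 40 nM
- compound 3 `Nc1ncnn2c([C@@H]3O[C@H](CO)[C@@H](O)[C@H]3O)cc(-c3ccc(F)cc3F)c12`: 69700 nM

Compound 3 stands highest of the three, and thus weakest. Compound 4 `Nc1ncnn2c([C@@H]3O[C@H](CO)[C@@H](O)[C@H]3O)cc(-c3ccoc3)c12` replaces its 2,4-difluorophenyl with furan-3-yl: furan-3-yl in place of 2,4-difluorophenyl on an aromatic carbon. Among the measured compounds shown here, two measured steps bear directly on this place, a 63-fold higher number from compound 1 to compound 3 (1.80 log units; beyond the scatter) and a 1700-fold higher number from compound 2 to compound 3 (3.24 log units; beyond the scatter). A third, a 28-fold lower number from compound 1 to compound 2 (1.44 log units; beyond the scatter), shows how far the numbers move among the alkynes alone. For the measured compounds named here, compound 3 is the only aryl compound measured, and no compound with a five-membered aromatic ring at this place has been measured, so the size of the change stays uncertain. A large step toward a lower number is nonetheless expected, estimated as a 46-fold lower number from compound 3 to compound 4 (1.67 log units; beyond the scatter). Compound 4 is estimated at 1500 nM, with an expected range of 100 nM to 20000 nM.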

Compound 4, half-maximal inhibitory concentration: 2100 nM
Estimate against measurement, compound 4: 1.4-fold (0.15 log units) below; the range from low to high includes it.
By their numbers in this assay, from the lowest: compound 2; then compounds 1 and 4 (each within the scatter of the next); then compound 3.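

Swapping the 2,4-difluorophenyl for furan-3-yl recovers much of the activity lost with that aryl group (a 33-fold lower number from compound 3 to compound 4 (1.52 log units; beyond the scatter)), so an aromatic ring at this place is not weak in itself. Furan-3-yl still falls well short of 2-cyclopropylethynyl (a 53-fold higher number from compound 2 to compound 4 (1.72 log units; beyond the scatter)), whereas its step from pent-1-yn-1-yl stays within the scatter (a 1.9-fold higher number from compound 1 to compound 4 (0.28 log units; within the scatter)), so it matches one alkyne but not the other. No measured evidence is available to explain these differences. On these data alone, it remains open whether the smaller ring or its oxygen carries the gain. Thiophen-3-yl and unsubstituted phenyl at this place could fall nearer either compound 3 or compound 4.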